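The source may report more compounds than this note shows. Statements on the series, on what has been measured and on what is new or still open speak of the compounds shown alone.

Measured compounds:
compound 1, `O=S(=O)(Nc1ccc2oc(-c3ccc(NS(=O)(=O)c4cccc5nonc45)cc3)nc2c1)c1ccc(Cl)s1`: 11000 nM
compound 2, `O=[N+]([O-])c1cc(S(=O)(=O)Nc2ccc(-c3nc4cc(NS(=O)(=O)c5ccc(Cl)s5)ccc4o3)cc2)ccc1Cl`: 2100 nM

Among the compounds with values here, in an assay for inhibition of HSP60/HSP10 (Homo sapiens), with a stated time of 60 min (on this read-out higher numbers stand for weaker inhibition and lower numbers for stronger inhibition), compound 2 stands lowest of the two numbers, with compound 1 the nearest, and the only step measured, a 5.2-fold lower number from compound 1 to compound 2 (0.72 log units; beyond the scatter), replaces the whole group on the sulfonyl sulfur rather than a single substituent on it. Compound 3, `O=S(=O)(Nc1ccc(-c2nc3cc(NS(=O)(=O)c4ccc(Cl)s4)ccc3o2)cc1)c1ccc(Cl)c(C(F)(F)F)c1`, differs from compound 2 by trifluoromethyl in place of nitro on an aromatic carbon. Within the data shown here, the measured step bears on this change only loosely, since both touch the same group but not in the same way; no step of the nitro-to-trifluoromethyl kind has been measured. A step within the scatter, or at most a modest one in either direction, is expected. For compound 3 the estimate is 2500 nM (range 800 nM to 8000 nM), an expected step of a 1.2-fold higher number from compound 2 to compound 3 (0.08 log units; within the scatter).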

Compound 3, half-maximal inhibitory concentration: 6100 nM
Compound 3: the middle estimate sits 2.4-fold (0.39 log units) below what was measured; the measured number falls inside the stated range.
By their numbers in this assay, from the lowest: compound 2; then compounds 3 and 1 (each within the scatter of the next).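

In this assay, within the data shown here, the first change on this aromatic carbon, trifluoromethyl in place of nitro, reads a 2.9-fold higher number from compound 2 to compound 3 (0.46 log units; beyond the scatter), so nitro is not freely exchangeable here. Against the group on the sulfonyl sulfur of compound 1, the step reads a 1.8-fold lower number from compound 1 to compound 3 (0.26 log units; within the scatter), so the gain seen with the 4-chloro-3-nitrophenyl group does not clearly persist with 4-chloro-3-(trifluoromethyl)phenyl. No evidence at hand accounts for the step.

Open, going by these compounds, is how an amine or a carboxylic acid on this carbon would read. Also open, on these data alone, is whether the step holds without the chloro group.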